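Chloro in Place of Fluoro: Expecting Little Change

A few compounds are considered here, and "the series" means these few. Any claim that something is new, unique, unknown or untested is made for them only; others in the source may bear on it.

Compound 1 `CCS(=O)(=O)Nc1cc(-c2ccc3ncnc(Nc4ccc(F)cc4)c3c2)cnc1OC` gives 3120 nM in a functional assay on BT-549 cells (Homo sapiens) for cytotoxicity, read by sulforhodamine B assay, with a stated time of 72 h; on this read-out lower numbers stand for stronger inhibition and higher numbers for weaker inhibition. Compound 2 `CCS(=O)(=O)Nc1cc(-c2ccc3ncnc(Nc4ccc(F)c(C(=O)OC)c4)c3c2)cnc1OC` carries a methoxycarbonyl group where compound 1 has hydrogen, and in this assay compound 2 gives 2740 nM. The step of a 1.1-fold lower number from compound 1 to compound 2 (0.06 log units; within the scatter) shows that compounds 1 and 2 sit within the usual scatter of each other, so neither can be called the stronger of the two. Compound 3 `CCS(=O)(=O)Nc1cc(-c2ccc3ncnc(Nc4ccc(Cl)c(C(=O)OC)c4)c3c2)cnc1OC` differs from compound 2 by chloro in place of fluoro on an aromatic carbon. Among the measured compounds shown here, no measured step touches this kind of exchange: the only step known, from compound 1 to compound 2, concerns another group on the same ring and was itself within the scatter. With nothing pointing in either direction, a change no larger than the scatter is expected from compound 2 to compound 3, as a 1.1-fold lower number from compound 2 to compound 3 (0.04 log units; within the scatter). Compound 3 is therefore estimated at 2500 nM, with a range from 1200 nM to 5500 nM.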

Compound 3, half-maximal inhibitory concentration: 2360 nM
Compound 3: the middle estimate sits 1.1-fold (0.03 log units) above what was measured; measured number inside the range.
By their numbers in this assay, from the lowest: compounds 3, 2 and 1 (each within the scatter of the next).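

In this assay, chloro in place of fluoro, at the position ortho to a methoxycarbonyl group and para to a large group, gives a 1.2-fold lower number from compound 2 to compound 3 (0.06 log units; within the scatter) and so cannot be told apart from the scatter. Among the compounds shown here, this is the first sign that the position takes either of these two halogens with no measurable difference on this read-out. The larger exchange of 4-chloro-3-(methoxycarbonyl)phenyl in place of 4-fluorophenyl on the nitrogen gives a 1.3-fold lower number from compound 1 to compound 3 (0.12 log units; within the scatter) and also stays within the scatter, and no measurement at hand gives any reason for these small steps.

The compounds shown leave open whether a group other than a halogen at this position, such as an amine or a nitrile, would shift the number beyond the scatter. They also leave open what a carboxylic acid in place of the methoxycarbonyl group would do.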